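Swapping the Aryl Group on the Sulfonamide Sulfur

A few compounds are considered here, and "the series" means these few. Any claim that something is new, unique, unknown or untested is made for them only; others in the source may bear on it.

Of the compounds shown here, three sharing one core have so far been measured in an assay on MDA-MB-231 cells for displacement of a labelled ligand from C-X-C chemokine receptor type 4 (Homo sapiens), read by fluorescence and microscopy, with stated times of 10 min and 30 min; a lower number here means that less compound is needed, a higher number that more compound is needed for the effect. Compound 1, `COc1ccccc1C(=O)NCc1ccc(CNS(=O)(=O)c2cccc(C)c2)cc1`, gives 1000 nM. Compound 3, `COc1ccccc1C(=O)NCc1ccc(CNS(=O)(=O)c2cccc(Cl)c2)cc1`, gives 1000 nM, and the step of no change at the digits printed from compound 1 to compound 3 (within the scatter) shows that chloro in place of methyl on an aromatic carbon leaves the number where it was. Compound 2, `COc1ccccc1C(=O)NCc1ccc(CNS(=O)(=O)c2cccc3ccccc23)cc1`, reaches only the limit of this assay, > 1000 nM. Because of the limit of > 1000 nM in this assay, at which 1 of the 3 values shown sits, the steps of a number no lower from compound 1 to compound 2 (the limit leaves the size open) and a number no higher from compound 2 to compound 3 (the limit leaves the size open) cannot be sized. Compound 3 thus stands level with compound 1, with one further value in the set being a limit.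

Compound 4, `COc1ccccc1C(=O)NCc1ccc(CNS(=O)(=O)c2ccccc2F)cc1`, is not yet measured. It differs from compound 3 by 2-fluorophenyl in place of 3-chlorophenyl on a sulfonyl sulfur. Within the data shown here, the only sized step involving the ring on the sulfonyl sulfur is no change at the digits printed from compound 1 to compound 3 (within the scatter), which lay within the scatter; no measured step covers 2-fluorophenyl. The expected step is therefore no change at the digits printed from compound 3 to compound 4 (within the scatter), within the scatter. Compound 4 is estimated at 1000 nM, between 400 nM and 2500 nM.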

Compound 4, effective concentration (reported as EC, without a stated level of effect): 1 nM
Compound 4: middle estimate off by 1000-fold (3.00 log units), on the high side; measured number outside the range, below it.
By their numbers in this assay, from the lowest: compound 4; then compounds 1 and 3 (each within the scatter of the next).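

In this assay, the ring on the sulfonyl sulfur proves far from indifferent, although the swap between compound 1 and compound 3 left the number unchanged: 2-fluorophenyl in place of 3-chlorophenyl gives a 1000-fold lower number from compound 3 to compound 4 (3.00 log units; beyond the scatter), and in place of 3-methylphenyl it gives a 1000-fold lower number from compound 1 to compound 4 (3.00 log units; beyond the scatter). In place of naphthalen-1-yl, the same group gives an at least 1000-fold lower number from compound 2 to compound 4 (3.00 log units; beyond the scatter). The value of compound 2 is a limit, so this last step has only a minimum size: the limit of > 1000 nM in this assay, at which 1 of the 4 values shown sits.

Still open, as far as these compounds go, is whether 3-fluorophenyl or 2-chlorophenyl would also give so low a number, which would separate the effect of the fluoro from that of its place on the ring. How a 2-methoxyphenyl or 2-aminophenyl group on the sulfonyl sulfur would read is open as well.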